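A few compounds are considered here, and "the series" means these few. Any claim that something is new, unique, unknown or untested is made for them only; others in the source may bear on it.

Measured compounds in a functional assay on T47D cells (Homo sapiens) for inhibition; on this read-out lower numbers stand for stronger inhibition and higher numbers for weaker inhibition:

Compound 1 `Oc1ccc(-c2cc(-c3cccc(C(F)(F)F)c3)cc(-c3ccccc3O)n2)cc1`: in this assay compound 1 gives > 50000 nM, which is a limit of the assay and not a number.
Compound 2 `Oc1ccc(-c2cc(-c3ccc(C(F)(F)F)cc3)cc(-c3ccccc3O)n2)cc1`: in this assay compound 2 gives > 50000 nM, again a limit and not a number.
Compound 3 `Oc1cccc(-c2cc(-c3cccc(C(F)(F)F)c3)cc(-c3cccc(O)c3)n2)c1`: in this assay compound 3 gives 4970 nM.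

Going by the values given here, compound 3 thus supplies the only real number among the three; the other two sit at the limit of > 50000 nM in this assay, at which 2 of the 3 values shown sit. The change from compound 1 to compound 2 is 4-(trifluoromethyl)phenyl in place of 3-(trifluoromethyl)phenyl on an aromatic carbon, and its size in this assay is a step that the two limits leave unreadable from compound 1 to compound 2, because both values rest at the limit of > 50000 nM in this assay, at which 2 of the 3 values shown sit. The difference between the cores of compound 1 and compound 3 is not broken down here.

Compound 4 `Oc1cccc(-c2cc(-c3ccc(C(F)(F)F)cc3)cc(-c3cccc(O)c3)n2)c1` has not yet been measured in this assay. The change from compound 3 to compound 4 is 4-(trifluoromethyl)phenyl in place of 3-(trifluoromethyl)phenyl on an aromatic carbon. This is the same kind of change as from compound 1 to compound 2, though not the same: in compound 1 the place is meta to a 2-hydroxyphenyl group and meta to a 4-hydroxyphenyl group, while in compound 3 it is meta to two 3-hydroxyphenyl groups.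

Since the earlier step could not be read, the expectation for compound 4 rests on compound 3 alone, whose value 4970 nM is the starting point, and on the assumption that moving the trifluoromethyl group changes little. The step from compound 3 to compound 4 is therefore estimated as a 1.4-fold higher number from compound 3 to compound 4 (0.15 log units; within the scatter). Compound 4 is expected to give about 7000 nM in this assay, likely between 2000 nM and 35000 nM.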

Compound 4, half-maximal inhibitory concentration: 2330 nM
The estimate for compound 4 lay 3.0-fold (0.48 log units) above the measured number; the measured number falls inside the stated range.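

In this assay, putting 4-(trifluoromethyl)phenyl in place of 3-(trifluoromethyl)phenyl on the core of compound 3 gives a 2.1-fold lower number from compound 3 to compound 4 (0.33 log units; beyond the scatter), a modest but real change on that core. The same change on the core of compound 1 cannot be read, because compound 1 and compound 2 both rest at a limit of the assay and not at a number: the limit of > 50000 nM in this assay, at which 2 of the 4 values shown sit. The series therefore gives one readable step on one core, which shows neither that the change carries over to the core of compound 1 nor that it fails to, and a single pair of compounds makes no general rule.

The compounds shown leave open which difference between the core of compound 1 and the core of compound 3 matters, since those two compounds differ in more than one place and their gap cannot be assigned to either hydroxyphenyl group alone. They also leave open whether the place opposite the ring nitrogen would accept something other than a trifluoromethylphenyl group, such as a phenyl ring carrying an amine or a carboxylic acid, and what that would do to the number in this assay.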